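Swapping a ring amine for a tert-butylamine on the sulfonyl

The source may report more compounds than this note shows. Statements on the series, on what has been measured and on what is new or still open speak of the compounds shown alone.

Measured so far:
Compound 1, `O=C(Nc1cccc(S(=O)(=O)N2CCCC2)c1)c1cccnc1N1CCC2(CC1)CC2`, gives 5460 nM in a functional assay on OVCAR-3 cells (Homo sapiens) for activation, with a stated time of 24 h; a lower number here means that less compound is needed, a higher number that more compound is needed for the effect.
Compound 2, `CC(C)(C)NS(=O)(=O)c1cccc(NC(=O)c2ncc(NS(C)(=O)=O)nc2N2CCC3(CC2)CC3)n1`, gives 32 nM in this assay.
Compound 3, `O=C(Nc1cccc(S(=O)(=O)C2CCCC2)c1)c1cccnc1N1CCCCC1`, gives 6350 nM in this assay.

Among these three numbers compound 1 has the second highest, meaning a fairly large amount is needed for the effect. Compound 3 sits very close, and the two are within the usual scatter of each other, so no order between them can be claimed. Compound 2 stands far apart, needing a much smaller amount, but it differs from compound 1 in several places at once, so its number alone does not show which change matters.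

Compound 4, `CC(C)(C)NS(=O)(=O)c1cccc(NC(=O)c2cccnc2N2CCC3(CC2)CC3)c1`, has not yet been measured. It differs from compound 1 in one place: (tert-butyl)amino in place of pyrrolidin-1-yl on a sulfonyl sulfur.

Among the measured compounds shown here, no single-change step between measured compounds is available to guide this. The same kind of sulfonyl group does appear in compound 2, which gives 32 nM, yet too much else is different there. The step from compound 1 to compound 4 is therefore expected to be a moderately lower number, a 2.2-fold lower number from compound 1 to compound 4 (0.34 log units; beyond the scatter), possibly no further than the scatter. Compound 4 is expected to give about 2500 nM, within a range from 600 nM to 8000 nM.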

Compound 4, half-maximal effective concentration: 1030 nM
Beside the measured number, compound 4's estimate is 2.4-fold (0.39 log units) above it; the range from low to high includes it.
By their numbers in this assay, from the lowest: compound 2; then compound 4; then compounds 1 and 3 (each within the scatter of the next).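

In this assay, among the compounds shown here, replacing pyrrolidin-1-yl with (tert-butyl)amino on a sulfonyl sulfur gives a 5.3-fold lower number from compound 1 to compound 4 (0.72 log units; beyond the scatter) and provides the first comparison here in which only one part of the molecule differs. The two groups have the same number of heavy atoms, made up of the same elements, so this position distinguishes between groups that match in those counts but differ in their arrangement: the group that leaves has a ring and no hydrogen-bond donor, while the group that enters has no ring and one hydrogen-bond donor. Nothing measured here explains the lower number, so the step stands as an observation only.

The compounds shown leave open whether the loss of the ring or the gain of the hydrogen-bond donor accounts for the step, since both changes occur together; a cyclopentylamino group, which keeps a ring and a donor, and a tert-butyl(methyl)amino group, which has no ring and no donor, could help separate the two. From the compounds shown here alone, it also remains open whether a smaller group such as methylamino or a larger one such as adamantylamino would fit this position on the sulfonyl sulfur.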